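Notes on an aryl-ether variant of compound 1

A few compounds are considered here, and "the series" means these few. Any claim that something is new, unique, unknown or untested is made for them only; others in the source may bear on it.

Measured so far:
- compound 1, `C1=C(c2cncc(OCc3ccccc3)c2)CC2CNCC1C2`: 44 nM
- compound 2, `CN1C[C@@H]2C=C(c3cccnc3)C[C@@H](C2)C1`: 1800 nM

Both numbers come from an in vitro assay on SH-SY5Y cells for displacement of a labelled ligand from Neuronal acetylcholine receptor; alpha3/beta4 (Homo sapiens); on this read-out higher numbers stand for weaker inhibition and lower numbers for stronger inhibition. Compound 1 holds the lower of the two values; compound 2 sits far above it, and the gap between them is well beyond the usual scatter. The two compounds differ in several places at once, so the gap cannot be assigned to any single part of the structure; it only shows that the substitution pattern of compound 1 is the better starting point of the pair.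

Compound 3, `COc1ccc(Oc2cncc(C3=CC4CNCC(C3)C4)c2)cc1`, has not yet been measured. Its difference from compound 1 is 4-methoxyphenyl in place of benzyl on an oxygen on an aromatic ring. The oxygen on the aromatic ring is kept, as is the rest of the shared core; only the group on that oxygen changes, with 4-methoxyphenyl entering where benzyl leaves.

For the measured compounds named here, no measured step of this kind exists. The expectation in this assay is a modest weakening, a step that may well remain within the scatter, given as a 2.0-fold higher number from compound 1 to compound 3 (0.31 log units; beyond the scatter). Compound 3 is therefore expected near 90 nM, with a plausible span from 15 nM to 500 nM.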

Compound 3, inhibition constant: 27 nM
For compound 3 the middle estimate is 3.3-fold (0.52 log units) above the measured one, within the range that was stated.
By their numbers in this assay, from the lowest: compounds 3 and 1 (each within the scatter of the next); then compound 2.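

In this assay, 4-methoxyphenyl in place of benzyl on the oxygen on the aromatic ring gives a 1.6-fold lower number from compound 1 to compound 3 (0.21 log units; within the scatter), so this read-out does not tell the two groups apart. The earlier compounds shown here offered no step at this position; this one shows that the group on that oxygen can be exchanged, with 8 heavy atoms and 1 hydrogen-bond acceptor entering for 7 heavy atoms and none, without a difference that stands clear of the scatter. No measurement at hand accounts for the two groups reading alike, and a single step speaks for this pair only.

Open, from the compounds shown here alone, is whether the methoxy group of 4-methoxyphenyl contributes anything at all, since plain phenyl on the same oxygen would separate its part from that of the ring it sits on. Also open, going by these compounds, is how much this position takes before the value moves beyond the scatter, for instance with a carboxylic acid or an amine on that ring, or with a longer chain such as phenethyl on the oxygen.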